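The source may hold more compounds than are shown below. What is called first, only, known or untested is meant among the compounds shown, and "the series" means these compounds.

Measured so far:
- Compound 1, `O=C(CSc1ncc[nH]1)Nc1ccc2nc(NC(=O)c3ccc(C(F)(F)F)cc3)sc2c1`: 2690 nM
- Compound 2, `CCCC(=O)Nc1nc2ccc(NC(=O)CSc3cccc(O)c3)cc2s1`: 10600 nM
- Compound 3, `O=C(CSc1cccc(O)c1)Nc1ccc2nc(NC(=O)c3ccc4ccccc4c3)sc2c1`: 4250 nM

All three were tested in a functional assay on HCT-116 cells (Homo sapiens) for antiproliferative activity, read by MTT assay, with a stated time of 72 h; a lower number here means a stronger inhibitor, a higher number a weaker inhibitor. Compound 1 gives 2690 nM, the lowest of the three numbers. Its nearest neighbour is compound 3, whose value lies within the usual scatter of compound 1, so no order can be read between the two. Compound 2 stands furthest away, and the gap between compound 1 and compound 2 is beyond the scatter.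

Among the compounds with values here, only one step between measured compounds is available: a 2.5-fold lower number from compound 2 to compound 3 (0.40 log units; beyond the scatter). That step changes the group on a carbonyl carbon, on the other side of the shared core, and says nothing direct about the sulfur-bearing side.

Compound 4, `O=C(CSc1ccc(Cl)cc1)Nc1ccc2nc(NC(=O)c3ccc(C(F)(F)F)cc3)sc2c1`, differs from compound 1 only there: 4-chlorophenyl in place of 1H-imidazol-2-yl on a sulfur. Within the data shown here, no measured step tests this exact exchange. The closest hint is that compound 1 and compound 3, which carry different groups on the same sulfur, sit within the scatter of each other. A small step at most is therefore expected for this assay, with no clear direction. The estimate for compound 4 is 2500 nM, between 1000 nM and 6500 nM, a step of a 1.1-fold lower number from compound 1 to compound 4 (0.03 log units; within the scatter) that is expected to stay within the scatter.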

Compound 4, half-maximal inhibitory concentration: 930 nM
Compound 4: middle estimate off by 2.7-fold (0.43 log units), on the high side, outside the stated range (below it).
By their numbers in this assay, from the lowest: compound 4; then compounds 1 and 3 (each within the scatter of the next); then compound 2.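

In this assay, within the data shown here, the group on the sulfur does change the result: with everything else in the molecule held the same, putting 4-chlorophenyl in place of 1H-imidazol-2-yl gives a 2.9-fold lower number from compound 1 to compound 4 (0.46 log units; beyond the scatter) and this is the only measured step at this position. Among these compounds, the earlier compounds could not show this, since the one step available among them changed a group on a carbonyl carbon and left the group on this sulfur untouched. The exchange alters several things at once, replacing a five-membered ring with 2 hetero atoms, 1 hydrogen-bond donor and 1 hydrogen-bond acceptor by a six-membered ring of carbon only that carries a chlorine, and no measurement here explains why the number falls.

This single pair cannot separate the chlorine from the ring that carries it, a question that a plain phenyl, a 4-fluorophenyl or a saturated cyclohexyl on the same sulfur would address. It also leaves open whether a ring bearing an amine or a carboxylic acid would fit here, and whether the same exchange holds when propyl or naphthalen-2-yl sits on the carbonyl carbon.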